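The compounds below may be only part of what the source reports. "The series", "measured", "known", "first", "only" and "open" are said of these compounds alone.

Measured in a functional assay on the whole organism for inhibition, with Rattus norvegicus as the target, read by paw edema, at a dose of 100 mg/kg by the oral route; on this read-out lower numbers stand for less inhibition and higher numbers for more inhibition at the one dose given (going by the name of the read-out):
Compound 1 `O=C(NCc1ccccc1)c1c(O)c2cccnc2n(-c2ccccc2)c1=O`: 1.6%
Compound 2 `COc1ccccc1NC(=O)c1c(O)c2cccnc2n(-c2ccccc2)c1=O`: 8.1%

Going by the values given here, compound 2 is one of two compounds with a number in this assay; the single step of a number 6.5 percentage points higher from compound 1 to compound 2 (within the scatter) lies within the scatter, so the two cannot be told apart. Compound 3 `O=C(Nc1ccncc1)c1c(O)c2cccnc2n(-c2ccccc2)c1=O` differs from compound 2 by pyridin-4-yl in place of 2-methoxyphenyl on an amide-type nitrogen. Among the compounds with values here, the one measured step also swapped the group on the amide-type nitrogen and stayed within the scatter; no measured compound carries pyridin-4-yl. The expected step in this assay is therefore small, a number 2.1 percentage points lower from compound 2 to compound 3 (within the scatter), with no clear direction. Compound 3 is estimated at 6%, ranging from 0% to 20%.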

Compound 3, a percentage reported as inhibition, in the whole organism at one dose (the size of the read-out at that dose, not a potency): 34.9%
For compound 3 the middle estimate is 28.9 percentage points below the measured one; measured number outside the range, above it.
By their numbers in this assay, from the lowest: compounds 1 and 2 (each within the scatter of the next); then compound 3.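

In this assay the group on the amide-type nitrogen can change the outcome, with a number 26.8 percentage points higher from compound 2 to compound 3 (beyond the scatter) and a number 33.3 percentage points higher from compound 1 to compound 3 (beyond the scatter) when pyridin-4-yl enters, whereas the earlier swap at this nitrogen could not be told apart from scatter. Among the compounds shown, only pyridin-4-yl brings a ring nitrogen to this place. Nothing measured here explains the gain.

Still open, on these data alone, is whether the gain belongs to that ring nitrogen or to the loss of the methoxy group. A plain phenyl on the same nitrogen would separate these, and pyridin-3-yl would test whether the place of the ring nitrogen counts.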